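Urea Series: Amino for Methyl and Expected Solubility

This account rests on a few compounds, and the source may have more. Where it says the series, first, only, none or still open, it means among the compounds named here.

Measured so far in a physicochemical assay for solubility, at pH 7.4; on this read-out lower numbers stand for lower solubility and higher numbers for higher solubility:
- compound 1, `Cc1cc(NC(=O)Nc2cccc(C(N)=O)c2)c2ccccc2n1`: 100 nM
- compound 2, `Cc1ccc(NC(=O)Nc2cc(C)nc3ccccc23)cc1`: 1300 nM

Compound 2 stands highest of the two numbers in this assay, and its nearest neighbour, compound 1, sits a good deal lower, a gap beyond the usual scatter. Within the data shown here, no single-point step between measured compounds is available, since compound 1 and compound 2 differ in more than one place; their two values show only that the series spans a wide range.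

Compound 3, `Cc1cc(NC(=O)Nc2ccc(N)cc2)c2ccccc2n1`, has not yet been measured. It differs from compound 2 in one place: amino in place of methyl on an aromatic carbon. The change, amino in place of methyl on an aromatic carbon, is the whole of the difference.

In this assay the step is expected to be upward and moderate, because compound 2 already gives 1300 nM and the step of a 2.3-fold higher number from compound 2 to compound 3 (0.36 log units; beyond the scatter) is estimated to move the number higher, beyond the scatter but not by a very large amount. Compound 3 is estimated at 3000 nM, with a likely range from 800 nM to 12000 nM.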

Compound 3, solubility: 18500 nM
Compound 3: middle estimate off by 6.2-fold (0.79 log units), on the low side, outside the stated range (above it).
By their numbers in this assay, from the lowest: compound 1; then compound 2; then compound 3.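

In this assay, among these compounds, the change from 4-methylphenyl to 4-aminophenyl, on an aromatic carbon para to a large group, comes with a 14-fold higher number from compound 2 to compound 3 (1.15 log units; beyond the scatter), the first reading of a single change, since the two earlier compounds differ in more than one place and could show only the overall spread of values. This position is therefore one where swapping a single heavy atom, carbon for nitrogen, goes with a large shift in the read-out, with the rest of the structure held constant and an added hydrogen-bond donor and acceptor as the only counted difference. Nothing available explains the size of this step, which so far rests on this one pair of compounds.

The compounds shown leave open whether a dimethylamino group, a hydroxyl or a carboxylic acid at the same place would go with a step of similar size and direction. They also leave open whether amino in place of methyl would do the same at the other methyl, the one on the shared core, or on a compound with the different substitution of compound 1.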